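From 4-chlorophenyl to 3-chlorophenyl: compound 3 to compound 4

A few compounds are considered here, and "the series" means these few. Any claim that something is new, unique, unknown or untested is made for them only; others in the source may bear on it.

In an ADME assay on Raji cells (Homo sapiens) for cytotoxicity, with a stated time of 72 h (a lower number here means that less compound is needed, a higher number that more compound is needed for the effect), compound 1 `COC(=O)c1cccc(NC(=O)Nc2cc(C)nc3ccccc23)c1` gives 26000 nM and compound 2 `Cc1cc(NC(=O)Nc2cccc(C(F)(F)F)c2)c2ccccc2n1` gives 10000 nM. Compound 3 `Cc1cc(NC(=O)Nc2ccc(Cl)cc2)c2ccccc2n1` gives > 25000 nM, which is a limit and not a number. That places compound 3 at the limit of > 25000 nM in this assay, at which 1 of the 3 values shown sits.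

Compound 4 `Cc1cc(NC(=O)Nc2cccc(Cl)c2)c2ccccc2n1` has 3-chlorophenyl in place of 4-chlorophenyl on an amide-type nitrogen, with the same atoms joined differently (3-chlorophenyl in place of 4-chlorophenyl on an amide-type nitrogen).

Going by the values given here, no measured step moves a group from one place to another. The nearest guide is a 2.6-fold lower number from compound 1 to compound 2 (0.41 log units; beyond the scatter), a modest step beyond the scatter that exchanges one group for another. Compound 4 shares its substitution pattern with compound 1 and compound 2, so a modest move to a lower number is expected in this assay, although compound 3 gives no exact starting point. The expected change is an at least 1.7-fold lower number from compound 3 to compound 4 (0.25 log units; that floor lies within the scatter). The estimate for compound 4 is 14000 nM, with an expected range of 6000 nM to 30000 nM.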

Compound 4, half-maximal effective concentration: 18000 nM
For compound 4 the middle estimate is 1.3-fold (0.11 log units) below the measured one; measured number inside the range.
By their numbers in this assay, from the lowest: compounds 2, 4 and 1 (each within the scatter of the next, the first and the last beyond it).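

In this assay, going by these compounds alone, 3-chlorophenyl in place of 4-chlorophenyl on an amide-type nitrogen gives an at least 1.3-fold lower number from compound 3 to compound 4 (0.14 log units; that floor lies within the scatter), the first step here that keeps the chloro and changes only how it is joined. This step can be read only as a floor because compound 3 has a limit and not a number: the limit of > 25000 nM in this assay, at which 1 of the 4 values shown sits.
With the substitution pattern kept, chloro in place of trifluoromethyl gives a 1.8-fold higher number from compound 2 to compound 4 (0.26 log units; within the scatter) and chloro in place of methoxycarbonyl gives a 1.4-fold lower number from compound 1 to compound 4 (0.16 log units; within the scatter), so chloro is not separated from either group, although the two differ by a 2.6-fold lower number from compound 1 to compound 2 (0.41 log units; beyond the scatter).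

As far as these compounds go, the true size of the shift from 4-chlorophenyl to 3-chlorophenyl stays open. So does what an amine or a carboxylic acid on the same aromatic carbon would give in this assay.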